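The source may hold more compounds than are shown below. What is called first, only, known or untested is meant among the compounds shown, and "the series" means these compounds.

Compound 1 `CCn1c(C(=O)NCCN(C)C)ccc1C(CC)(CC)c1ccc(OCCC(O)(CC)CC)c(C)c1` gives 82 nM in an assay on cells for agonist activity at vitamin D3 receptor (Homo sapiens), with a stated time of 96 h; on this read-out lower numbers stand for an effect already at smaller amounts and higher numbers for an effect only at larger amounts of compound. Compound 2 `CCn1c(C(=O)Nc2ccc(OC(F)(F)F)cc2)ccc1C(CC)(CC)c1ccc(OCCC(O)(CC)CC)c(C)c1` gives > 10000 nM, which is a limit of the assay and not a number. Compound 3 `CCC(C)C(CO)NC(=O)c1ccc(C(CC)(CC)c2ccc(OCCC(O)(CC)CC)c(C)c2)n1CC` gives 450 nM.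

Among the two numbers shown, compound 3 stands highest; compound 1 is nearest, and the step of a 5.5-fold higher number from compound 1 to compound 3 (0.74 log units; beyond the scatter) lies beyond the scatter. Compound 4 `CCn1c(C(=O)N(C)CCO)ccc1C(CC)(CC)c1ccc(OCCC(O)(CC)CC)c(C)c1` differs from compound 3 in one place: (2-hydroxyethyl)(methyl)amino in place of (1-(hydroxymethyl)-2-methylbutyl)amino on a carbonyl carbon. The measured steps that bear on this change all sit on the same amide-type nitrogen. The step of a 5.5-fold higher number from compound 1 to compound 3 (0.74 log units; beyond the scatter) was modest, while an at least 120-fold higher number from compound 1 to compound 2 (2.08 log units; beyond the scatter) and an at least 22-fold lower number from compound 2 to compound 3 (1.34 log units; beyond the scatter) were large, the large ones involving the aryl-substituted compound 2, whose result is only a limit (the limit of > 10000 nM in this assay, at which 1 of the 3 values shown sits). The group entering compound 4 is, by the count given, shorter than the one leaving and without the branched alkyl, and is closer in count to the side chain of compound 1, which gave 82 nM. A modest step downward is therefore expected for compound 4, in the direction of compound 1, though not beyond the scatter with certainty. The expected step is a 2.3-fold lower number from compound 3 to compound 4 (0.35 log units; beyond the scatter). Compound 4 is estimated at 200 nM, with a range from 50 nM to 1000 nM.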

Compound 4, half-maximal effective concentration: 52.7 nM
Compound 4: the middle estimate sits 3.8-fold (0.58 log units) above what was measured, within the range that was stated.
By their numbers in this assay, from the lowest: compounds 4 and 1 (each within the scatter of the next); then compound 3. At a limit, above all of these: compound 2.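

In this assay, among the compounds shown here, the step of an 8.5-fold lower number from compound 3 to compound 4 (0.93 log units; beyond the scatter) shows that this carbonyl carbon tolerates a smaller group: the shorter (2-hydroxyethyl)(methyl)amino, with no branched alkyl, goes with a clearly lower number than (1-(hydroxymethyl)-2-methylbutyl)amino, and the earlier compounds showed no such change among hydroxyl-bearing groups. The step of a 1.6-fold lower number from compound 1 to compound 4 (0.19 log units; within the scatter) adds that a dimethylamino end on the chain is not needed to reach this level, since a hydroxyl-bearing chain on a nitrogen that also carries a methyl cannot be told apart from the chain of compound 1. The result for compound 2 is a limit of the assay and not a number, so the step of an at least 180-fold lower number from compound 2 to compound 4 (2.27 log units; beyond the scatter) gives only a minimum size for that gap: the limit of > 10000 nM in this assay, at which 1 of the 4 values shown sits.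

The change from compound 3 to compound 4 shortens the chain, removes the branch and replaces the amide hydrogen with a methyl all at once, so the compounds shown do not say which of these matters. Going by these compounds, it also stays open how a plain 2-hydroxyethyl group on the same nitrogen with its hydrogen kept, a longer 3-hydroxypropyl chain or a cyclic amine such as morpholine would compare.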